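A Third Difluorophenyl Isomer Enters the Aryl Series

The compounds below may be only part of what the source reports. "The series", "measured", "known", "first", "only" and "open" are said of these compounds alone.

Measured so far:
compound 1 `Nc1scc(CN2CCN(c3cccc(C(F)(F)F)c3)CC2)c1C(=O)c1ccc(Cl)cc1`: 0% in an assay on CHO cells for displacement of a labelled ligand from adenosine receptor A3 (Homo sapiens), read by scintillation counting, with a stated time of 120 min, tested at 10 uM; a higher number here means more inhibition at the concentration tested (going by the name of the read-out), a lower number less inhibition
compound 2 `Nc1scc(CN2CCN(c3ccc(F)c(F)c3)CC2)c1C(=O)c1ccc(Cl)cc1`: 1% in this assay
compound 3 `Nc1scc(CN2CCN(c3c(F)cccc3F)CC2)c1C(=O)c1ccc(Cl)cc1`: 4% in this assay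

Compound 3 holds the highest of the three numbers, but the steps of a number 4 percentage points higher from compound 1 to compound 3 (within the scatter) and a number 3 percentage points higher from compound 2 to compound 3 (within the scatter) are both within the scatter, so none of the three numbers can be called higher than another. Compound 4 `Nc1scc(CN2CCN(c3cc(F)ccc3F)CC2)c1C(=O)c1ccc(Cl)cc1` is the next variation: 2,5-difluorophenyl in place of 2,6-difluorophenyl on an amine nitrogen in a ring. The step that bears most on it is the earlier exchange of one difluorophenyl pattern for another, a number 3 percentage points higher from compound 2 to compound 3 (within the scatter), which was within the scatter, as was a number 1 percentage points higher from compound 1 to compound 2 (within the scatter). The step of a number 1 percentage points lower from compound 3 to compound 4 (within the scatter) is therefore expected to stay within the scatter. Compound 4 is estimated at 3%, with a range of 0% to 12%.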

Compound 4, a percentage reported as inhibition, at one concentration (the size of the read-out at that concentration, not a potency): 2%
Beside the measured number, compound 4's estimate is 1 percentage points above it, and the stated range covers the measured number.
By their numbers in this assay, from the lowest: compounds 1, 2, 4 and 3 (each within the scatter of the next).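

In this assay a third difluorophenyl pattern on the amine nitrogen in a ring leaves the series undivided, with a number 2 percentage points lower from compound 3 to compound 4 (within the scatter) and a number 1 percentage points higher from compound 2 to compound 4 (within the scatter) and also a number 2 percentage points higher from compound 1 to compound 4 (within the scatter). At this position, the 2,5-difluorophenyl group therefore cannot be told apart from the 2,6-difluorophenyl, 3,4-difluorophenyl or 3-(trifluoromethyl)phenyl groups. No evidence at hand bears on this result. As far as these compounds go, it remains open whether a carboxylic acid or an amine on the aryl group would give a number beyond the scatter, or whether changes elsewhere on the shared core would.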